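The source may hold more compounds than are shown below. What is called first, only, known or untested is meant among the compounds shown, and "the series" means these compounds.

Measured compounds in a functional assay on cells (Endothelial cell, Bos taurus) for antiproliferative activity; on this read-out higher numbers stand for weaker inhibition and lower numbers for stronger inhibition:
- compound 1 `COc1ccc(/C(F)=C\c2cc(OC)c(OC)c(OC)c2)cc1N`: 2100 nM
- compound 2 `COc1ccc(/C(F)=C/c2cc(OC)c(OC)c(OC)c2)cc1N`: 111000 nM

Compound 1 gives the lower of the two numbers in this assay, and compound 2 the higher; the step is a 53-fold higher number from compound 1 to compound 2 (1.72 log units; beyond the scatter). The only cause that can be pointed to for this step is the fact that compounds 1 and 2 differ only in the configuration as drawn, the double bond drawn E in compound 1 and Z in compound 2, with every atom and bond otherwise the same.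

Compound 3 `COc1ccc(/C(F)=C\c2cc(OC)c(OC)c(OC)c2)cc1F` is not yet measured. It is reached from compound 1 by fluoro in place of amino on an aromatic carbon; the amino leaves and the fluoro enters at a position ortho to a methoxy group and meta to a large group, while the double bond keeps the configuration of compound 1.

Within the data shown here, no measured step bears on this change: the single step in hand, from compound 1 to compound 2, concerns only the configuration of the double bond, and no pair swaps a substituent on the aromatic ring. The expectation for compound 3 therefore rests on the unchanged configuration alone, and the step from compound 1 is expected to be a 1.4-fold higher number from compound 1 to compound 3 (0.15 log units; within the scatter), which is within the scatter or close to it. Compound 3 is thus estimated at 3000 nM in this assay, with a range from 700 nM to 13000 nM.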

Compound 3, half-maximal inhibitory concentration: 23000 nM
Beside the measured number, compound 3's estimate is 7.7-fold (0.88 log units) below it; measured number above the stated range.
By their numbers in this assay, from the lowest: compound 1; then compound 3; then compound 2.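

In this assay, among these compounds, fluoro in place of amino on an aromatic carbon, ortho to a methoxy group and meta to a large group, is the first change to a ring substituent that can be read, and it gives an 11-fold higher number from compound 1 to compound 3 (1.04 log units; beyond the scatter). With the double bond kept as in compound 1, this position is therefore not indifferent to the group it carries, and the number in this assay responds to the amino-to-fluoro swap as well as to the configuration of the double bond. Nothing at hand bears on what lies behind this step.

From the compounds shown here alone, whether the step follows from the loss of the amino group or from the entry of the fluoro remains open, and a hydroxy group, a methyl group or plain hydrogen at this position would help separate the two. Also open, going by these compounds, is whether a substituted amine such as an acetamide would stay close to compound 1, and whether the same swap would give a step of similar size with the double bond drawn as in compound 2.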